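The source may report more compounds than this note shows. Statements on the series, on what has been measured and on what is new or still open speak of the compounds shown alone.

Compound 1 `O=c1oc(CO)cc2ccccc12` gives 118 ug/mL in a functional assay on PC-3 cells (Homo sapiens) for antiproliferative activity, read by sulforhodamine B assay, with a stated time of 48 h; a lower number here means a stronger inhibitor of growth, a higher number a weaker inhibitor of growth.
Compound 2 `COc1ccc2cc(CO)oc(=O)c2c1` gives 49.2 ug/mL in this assay.

Going by the values given here, of these two, compound 2 has the lower number, and the only measured step, a 2.4-fold lower number from compound 1 to compound 2 (0.38 log units; beyond the scatter), is what sets it apart; that step came from a methoxy in place of hydrogen on an aromatic carbon. Compound 3 `COc1ccc2cc(CCCO)oc(=O)c2c1` is not yet measured. It differs from compound 2 at one place: 2-hydroxyethyl in place of hydroxy on a saturated chain carbon bound to an aromatic carbon. Among the compounds with values here, no measured step bears on a change of this kind. Within the data shown here, the one known step, a 2.4-fold lower number from compound 1 to compound 2 (0.38 log units; beyond the scatter), concerns a group on the aromatic ring, not the chain that carries the hydroxy group, so it offers no guide to what lengthening that chain does. With nothing to lean on, the reasonable expectation for this assay is a step of no clear size, centred on no change beyond the scatter, with either direction possible and a wide spread. The estimate for compound 3 is therefore 45 ug/mL, with a range from 18 ug/mL to 110 ug/mL, which means an expected step of a 1.1-fold lower number from compound 2 to compound 3 (0.04 log units; within the scatter).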

Compound 3, concentration for 50% growth inhibition: 25.9 ug/mL
Beside the measured number, compound 3's estimate is 1.7-fold (0.24 log units) above it; the measured number falls inside the stated range.
By their numbers in this assay, from the lowest: compounds 3 and 2 (each within the scatter of the next); then compound 1.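

Lengthening hydroxymethyl to 3-hydroxypropyl gives a 1.9-fold lower number from compound 2 to compound 3 (0.28 log units; within the scatter) in this assay, which is the first reading on the chain that carries the hydroxy group rather than on the aromatic ring. Since this step lies within the usual scatter of repeated measurements, compound 2 and compound 3 cannot be told apart here, so the longer chain shows no measurable loss of growth inhibition, unlike the ring change in a 2.4-fold lower number from compound 1 to compound 2 (0.38 log units; beyond the scatter), which lay beyond the scatter. Nothing available accounts for how the chain change behaves in these cells.

On these data alone, with only these two chains on the methoxy-bearing core, it remains open whether a still longer chain would keep the same level of growth inhibition, or whether a chain ending in an amine or a carboxylic acid instead of hydroxy would shift the number beyond the scatter. As far as these compounds go, it is also open whether the same lengthening would give a similar result on the core of compound 1, which has hydrogen in place of the methoxy group.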